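Arylamino variations on a shared tricyclic core

The source may report more compounds than this note shows. Statements on the series, on what has been measured and on what is new or still open speak of the compounds shown alone.

Measured so far in a functional assay on MGC-803 cells (Homo sapiens) for inhibition, read by sulforhodamine B assay; a higher number here means a weaker inhibitor, a lower number a stronger inhibitor:
- compound 1, `O=C1C(Nc2ccc(Br)cc2)=CC(=O)c2c1nc1n2[C@H]2OC[C@@H](O)[C@H]2OC1`, gives 2020 nM
- compound 2, `O=C1C=C(Nc2ccccc2F)C(=O)c2c1nc1n2[C@H]2OC[C@@H](O)[C@H]2OC1`, gives 2080 nM

Compound 2 holds the highest of the two numbers in this assay, but the number of compound 1 lies within the scatter of it, so the two cannot be told apart. The next compound, compound 3, `Cc1ccc(NC2=CC(=O)c3nc4n(c3C2=O)[C@H]2OC[C@@H](O)[C@H]2OC4)cc1`, has not yet been measured in this assay.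

Change from compound 2 to compound 3: 4-methylphenyl in place of 2-fluorophenyl on an amine nitrogen

Both measured compounds carry an aryl group on the amine nitrogen and sit at nearly the same number, so the change to compound 3 is not expected to move this assay beyond the scatter. The step from compound 2 to compound 3 is estimated as a 1.0-fold lower number from compound 2 to compound 3 (0.02 log units; within the scatter). Compound 3 is expected at 2000 nM, with a range from 800 nM to 5000 nM.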

Compound 3, half-maximal inhibitory concentration: 1420 nM
Compound 3: middle estimate off by 1.4-fold (0.15 log units), on the high side, within the range that was stated.
By their numbers in this assay, from the lowest: compounds 3, 1 and 2 (each within the scatter of the next).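

In this assay, going by these compounds alone, 4-methylphenyl in place of 2-fluorophenyl on the amine nitrogen gives a 1.5-fold lower number from compound 2 to compound 3 (0.17 log units; within the scatter) and is the first step that differs in one place only. This nitrogen therefore accepts the exchange of these two aryl groups, with fluorine leaving and a methyl group entering, without a change that can be told from the scatter. No measurement at hand offers an explanation for this step.

The step alters both the substituent on the phenyl ring and its place on that ring, and these two changes cannot be separated from compound 2 and compound 3 alone. From the compounds shown here alone, whether the number holds with a non-aromatic group on this nitrogen, such as cyclohexyl or a longer alkyl chain, or with a carboxylic acid on the phenyl ring, remains open.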